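Benzylamino for dimethylamino on the shared core

The source may report more compounds than this note shows. Statements on the series, on what has been measured and on what is new or still open speak of the compounds shown alone.

Compound 1 `COc1cccc(Nc2nc(C)cc(N(C)C)n2)c1`, compound 2 `COc1cc(Nc2nc(C)cc(N(C)C)n2)ccc1F` and compound 3 `Cc1cc(N(C)C)nc(N[C@H]2CC[C@H](NC(=O)c3ccccc3)CC2)n1` share one core. In an ADME assay on Vero cells (Chlorocebus sabaeus) for cytotoxicity (a lower number here means that less compound is needed, a higher number that more compound is needed for the effect), compound 1 reaches only the limit > 50100 nM. Compound 3 likewise stops at the limit > 50100 nM. Among the measured compounds shown here, compound 2 gives 31600 nM, the only number among the three. Two of the three values sit at the limit of > 50100 nM in this assay, at which 2 of the 3 values shown sit. For the measured compounds named here, the single measured step, an at least 1.5-fold lower number from compound 1 to compound 2 (0.20 log units; that floor lies within the scatter), concerns fluoro in place of hydrogen and does not touch the position now in question. Compound 4 `COc1cc(Nc2nc(C)cc(NCc3ccccc3)n2)ccc1F` differs from compound 2 by benzylamino in place of dimethylamino on an aromatic carbon. Going by the values given here, no measured step bears on this change, so a step beyond the scatter in this assay cannot be derived in either direction. Compound 4 is expected at 22000 nM, within 8000 nM to 50100 nM. That estimate means a step of a 1.4-fold lower number from compound 2 to compound 4 (0.16 log units; within the scatter).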

Compound 4, half-maximal effective concentration: 5010 nM
Estimate against measurement, compound 4: 4.4-fold (0.64 log units) above, outside the stated range (below it).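

Benzylamino in place of dimethylamino gives a 6.3-fold lower number from compound 2 to compound 4 (0.80 log units; beyond the scatter), so this position, untouched by the earlier step, moves the read-out in this assay beyond the scatter. It is the only step shown that both lies beyond the scatter and joins two numbers rather than a number and a limit: the limit of > 50100 nM in this assay, at which 2 of the 4 values shown sit.

The compounds shown leave open whether the step goes with the ring or with the amine hydrogen of benzylamino. Methylamino, which carries that hydrogen without the ring, and phenethylamino, a longer chain, would separate the two.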